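A Shorter Amine Tail on the Shared Core

This account rests on a few compounds, and the source may have more. Where it says the series, first, only, none or still open, it means among the compounds named here.

Compound 1, `CN1CCN(CCCCCn2c3c(c4ccccc42)C(=O)c2c[n+]([O-])c4ccccc4c2C3=O)CC1`, gives 830 nM in a functional assay on SH-SY5Y cells (Homo sapiens) for cytotoxicity, read by MTT assay, with a stated time of 72 h; on this read-out higher numbers stand for weaker inhibition and lower numbers for stronger inhibition.
Compound 2, `O=C1c2c[n+]([O-])c3ccccc3c2C(=O)c2c1c1ccccc1n2Cc1cn([C@@H]2C[C@H](O)[C@@H](CO)O2)nn1`, gives 150 nM in this assay.
Compound 3, `O=C1c2c[n+]([O-])c3ccccc3c2C(=O)c2c1c1ccccc1n2Cc1cn([C@H]2O[C@H](CO)[C@@H](O)[C@H]2O)nn1`, gives 1340 nM in this assay.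

Compound 1 stands second highest of these three numbers; compound 3 sits within the scatter of it, while compound 2 lies beyond it. Among the compounds with values here, the only step measured between two compounds is an 8.9-fold higher number from compound 2 to compound 3 (0.95 log units; beyond the scatter), which concerns a sugar hydroxy and says nothing about the amine chain.

Compound 4, `O=C1c2c[n+]([O-])c3ccccc3c2C(=O)c2c1c1ccccc1n2CCCCN1CCCCC1`, differs from compound 1 in that (piperidin-1-yl in place of (4-methylpiperazin-1-yl)methyl on a saturated chain carbon, four bonds along the chain from an aromatic nitrogen). Within the data shown here, no measured step bears on this change, so no shift beyond the scatter is expected: a 1.2-fold lower number from compound 1 to compound 4 (0.07 log units; within the scatter) is the estimated step. Compound 4 is therefore estimated at 700 nM, with a range from 250 nM to 2000 nM.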

Compound 4, half-maximal inhibitory concentration: 230 nM
For compound 4 the middle estimate is 3.0-fold (0.48 log units) above the measured one, outside the stated range (below it).
By their numbers in this assay, from the lowest: compounds 2 and 4 (each within the scatter of the next); then compounds 1 and 3 (each within the scatter of the next).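

Changing the amine tail alone moves the number: piperidin-1-yl in place of (4-methylpiperazin-1-yl)methyl gives a 3.6-fold lower number from compound 1 to compound 4 (0.56 log units; beyond the scatter) in this assay, so this chain end is not a silent position. The earlier step concerned only a sugar hydroxy and could not show this. No measured evidence accounts for the shift.

The change swaps the ring and shortens the tail together, so the compounds shown cannot separate the two. Piperidin-1-yl on the longer tail, 4-methylpiperazin-1-yl on the shorter one, or a morpholine at the same chain end would leave open questions to test.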